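The compounds below may be only part of what the source reports. "The series", "measured", "known", "first", "only" and "open" are said of these compounds alone.

Of the compounds shown here, three built on one shared core have been measured in a functional assay on HCT-116 cells (Homo sapiens) for inhibition, read by MTT assay, with a stated time of 72 h, tested at 20 uM; a lower number here means less inhibition, a higher number more inhibition at the concentration tested (going by the name of the read-out). Compound 1 `c1cc(N2CCCC2)nc(Nc2ccc(Oc3ncnc4ccsc34)cc2)n1` gives 22.2%, the second highest of the three numbers. Compound 2 `c1ccc(CNc2ccc(Oc3ncnc4ccsc34)cc2)cc1` gives -12.2%, and compound 3 `CN(c1ccc(Oc2ncnc3sccc23)cc1)c1nccc(N2CCc3ccccc3C2)n1` gives 57.7%; both gaps from compound 1 lie beyond the usual scatter of such measurements. Compound 4 `c1ccc2c(c1)CCN(c1ccnc(Nc3ccc(Oc4ncnc5ccsc45)cc3)n1)C2` has not yet been measured. It differs from compound 1 in a single place: 1,2,3,4-tetrahydroisoquinolin-2-yl in place of pyrrolidin-1-yl on an aromatic carbon. Compound 3 also carries a 1,2,3,4-tetrahydroisoquinolin-2-yl group, and its value of 57.7% stands well above that of compound 1, so a rise is expected here. The expected step is estimated as a number 25.8 percentage points higher from compound 1 to compound 4 (beyond the scatter), beyond the scatter. Compound 4 is thus expected to give about 48%, most likely between 30% and 65%.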

Compound 4, a percentage reported as inhibition, at one concentration (the size of the read-out at that concentration, not a potency): 40.9%
Estimate against measurement, compound 4: 7.1 percentage points above, and the stated range covers the measured number.
By their numbers in this assay, from the lowest: compound 2; then compound 1; then compound 4; then compound 3.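

In this assay, within the data shown here, the change from pyrrolidin-1-yl to 1,2,3,4-tetrahydroisoquinolin-2-yl gives the first direct reading at this position on the shared core: a number 18.7 percentage points higher from compound 1 to compound 4 (beyond the scatter) on swapping one ring-bearing amine group for the other. The position therefore accepts the group with more heavy atoms without losing inhibition at the concentration tested.

On these data alone, whether the rise depends on the added six-membered aromatic ring of carbon only remains open, as does how a piperidin-1-yl or an open-chain diethylamino group would read at this place. Nothing available explains the rise.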